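The source may report more compounds than this note shows. Statements on the series, on what has been measured and on what is new or still open speak of the compounds shown alone.

In a functional assay on DU-145 cells (Homo sapiens) for cytotoxicity, read by trypan blue exclusion, with a stated time of 96 h (on this read-out lower numbers stand for stronger inhibition and higher numbers for weaker inhibition), compound 1 (`COC(=O)CNc1cc(NS(=O)(=O)/C=C/c2c(OC)cc(OC)cc2OC)ccc1OC`) gives 350 nM and compound 2 (`COc1cc(OC)c(/C=C/S(=O)(=O)Nc2ccc(OC)c(NC(C(=O)O)c3ccc(Cl)cc3)c2)c(OC)c1`) gives 75 nM as the lower of the two numbers. For the measured compounds named here, the only measured step shows a 4.7-fold lower number from compound 1 to compound 2 (0.67 log units; beyond the scatter) and it brought in the whole carboxy(4-chlorophenyl)methyl group, so it does not isolate the halogen. Compound 3 (`COc1cc(OC)c(/C=C/S(=O)(=O)Nc2ccc(OC)c(NC(C(=O)O)c3ccc(Br)cc3)c2)c(OC)c1`) carries the change bromo in place of chloro on an aromatic carbon with bromo in place of chloro on an aromatic carbon. Going by the values given here, no measured step exchanges one halogen for another, so no shift beyond the scatter is expected in this assay here. The expected step is a 1.1-fold lower number from compound 2 to compound 3 (0.03 log units; within the scatter) at most. Compound 3 is expected at 70 nM within an estimated range of 30 nM to 170 nM in this measurement.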

Compound 3, half-maximal inhibitory concentration: 250 nM
Beside the measured number, compound 3's estimate is 3.6-fold (0.55 log units) below it; the measured number lies above the stated range.
By their numbers in this assay, from the lowest: compound 2; then compounds 3 and 1 (each within the scatter of the next).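

In this assay the halogen proves not to be interchangeable at this position: bromo in place of chloro on an aromatic carbon, para to a large group, gives a 3.3-fold higher number from compound 2 to compound 3 (0.52 log units; beyond the scatter), the only step shown that isolates the halogen. Against the (methoxycarbonyl)methyl group, the (4-bromophenyl)(carboxy)methyl group gives a 1.4-fold lower number from compound 1 to compound 3 (0.15 log units; within the scatter), so the clear step seen with the chloro compound is not repeated with bromo. Nothing measured here accounts for the halogen's effect. On these data alone, whether fluoro or iodo on the same carbon would side with chloro or bromo stays open, as does how a plain phenyl without any halogen would compare.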